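The source may report more compounds than this note shows. Statements on the series, on what has been measured and on what is new or still open speak of the compounds shown alone.

Measured so far:
compound 1, `O=C1N(c2cccc(Cl)c2)CCN1C1CN2CCC1CC2`, gives 30.9 nM in a functional assay (Cavia porcellus) for antagonist activity at Serotonin 3 (5-HT3) receptor (Homo sapiens); on this read-out lower numbers stand for stronger inhibition and higher numbers for weaker inhibition
compound 2, `Cc1[nH]cnc1CN1CCN(c2cccc(Br)c2)C1=O`, gives 10.4 nM in this assay

Compound 2 stands at the lowest of these two numbers. Its nearest neighbour is compound 1, whose number is beyond the scatter of repeated measurements, so compound 2 is the stronger inhibitor of the two. The two compounds differ in several places at once, so the gap between them cannot be tied to any single change.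

Compound 3, `CSc1cccc(N2CCN(Cc3nc[nH]c3C)C2=O)c1`, has not yet been measured. It is built on compound 2 with one change: methylsulfanyl in place of bromo on an aromatic carbon. A bromo leaves and a methylsulfanyl enters, on an aromatic carbon of a six-membered aromatic ring of carbon only, meta to a large group. Among the compounds with values here, no measured pair shows what such an exchange does here, so nothing beyond the structural change itself supports an expectation. The expected step of a 1.4-fold higher number from compound 2 to compound 3 (0.16 log units; within the scatter) is small, a slight weakening at most, and may well lie within the scatter. Compound 3 is therefore estimated at 15 nM, with a range from 5 nM to 45 nM.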

Compound 3, antagonist equilibrium constant: 120 nM
For compound 3 the middle estimate is 8.0-fold (0.90 log units) below the measured one; measured number above the stated range.
By their numbers in this assay, from the lowest: compound 2; then compound 1; then compound 3.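

Within the data shown here, compound 2 and compound 3 are the first pair here that differ in one place, so the whole gap can be tied to a single exchange, which the first two compounds could not offer. In this assay the exchange of bromo for methylsulfanyl gives a 12-fold higher number from compound 2 to compound 3 (1.06 log units; beyond the scatter), a large weakening of inhibition, so this aromatic carbon, meta to a large group, is not indifferent to what sits on it, even though only one more heavy atom is added. Nothing available explains why this swap costs so much, and the size of the step alone does not point to any one feature of the new group.

The compounds shown leave open whether the loss goes with the sulfur, with the extra heavy atom or with the hydrogen-bond acceptor counted on methylsulfanyl, and a methyl or a methoxy group on this same carbon would help to separate these. They also leave open whether the same exchange would cost as much on the core of compound 1, which carries a chloro on its aromatic ring.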